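Aryl urea series: a second fluoro on compound 2

This account rests on a few compounds, and the source may have more. Where it says the series, first, only, none or still open, it means among the compounds named here.

Compound 1 `C[C@@H](NC(=O)Nc1ccccc1F)c1ccccc1`, compound 2 `C[C@@H](NC(=O)Nc1cccc(F)c1)c1ccccc1` and compound 3 `C[C@@H](NC(=O)Nc1cccc(Cl)c1)c1ccccc1` share one core and differ only in what sits on one six-membered aromatic ring of carbon only. In an ADME assay on the whole organism with Oryza sativa as the target, tested at 1 uM (on this read-out lower numbers stand for a stronger effect and higher numbers for a weaker effect at the one concentration tested), compound 1 gives 95%, compound 2 gives 95% and compound 3 gives 91%. Compound 2 stands level with compound 1 at the digits shown, the two together being the highest of the three numbers; its furthest neighbour by number is compound 3. Within the data shown here, the only single-point step among the measured compounds is a number 4 percentage points lower from compound 2 to compound 3 (within the scatter), chloro in place of fluoro, and it stays within the scatter.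

Compound 4 `C[C@@H](NC(=O)Nc1cccc(F)c1F)c1ccccc1` is not yet measured. It differs from compound 2 by fluoro in place of hydrogen on an aromatic carbon. Among the measured compounds shown here, no measured step puts a fluoro in place of hydrogen, so the nearest guide is the halogen exchange from compound 2 to compound 3, which moved nothing beyond the scatter. A step of similar size and of no clear direction is therefore expected, namely a number 2 percentage points lower from compound 2 to compound 4 (within the scatter). Compound 4 is estimated to give 93% in this assay, expected to fall between 85% and 99%.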

Compound 4, a percentage reported as activity, at one concentration (the size of the read-out at that concentration, not a potency): 99%
Compound 4: the middle estimate sits 6 percentage points below what was measured, and the stated range covers the measured number.
By their numbers in this assay, from the lowest: compounds 3, 1, 2 and 4 (each within the scatter of the next).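

In this assay, among these compounds, the only steps that put a fluoro in place of hydrogen on an aromatic carbon are a number 4 percentage points higher from compound 2 to compound 4 (within the scatter) and a number 4 percentage points higher from compound 1 to compound 4 (within the scatter). Compound 4 carries the fluoro of compound 1 and that of compound 2 together, so the second fluoro has now been read from both single-fluoro compounds, and in neither case does the step leave the scatter; a fluoro ortho to a fluoro group thus shows no effect that can be told apart from the scatter in these compounds. No supporting measurement is available to explain these numbers.

Going by these compounds, it remains open whether a group of another kind on this carbon, such as an amine or a carboxylic acid, would give a step beyond the scatter. The same question stands for a longer chain at this place.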